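Propoxy in place of hydroxy on the benzyl arm

A few compounds are considered here, and "the series" means these few. Any claim that something is new, unique, unknown or untested is made for them only; others in the source may bear on it.

Among the three compounds measured so far, compound 2 `Cc1ccc2[nH]c(=O)c(CN(Cc3ccc(O)cc3)Cc3ccc(C(C)(C)C)cc3)cc2c1` is the only one whose cytotoxicity comes back as a number: in a toxicity assay on MDCK cells (Canis lupus familiaris) for cytotoxicity, read by crystal violet staining, with a stated time of 48 h (on this read-out lower numbers stand for higher toxicity in this test and higher numbers for lower toxicity in this test), compound 2 gives 4900 nM. Compound 1 `Cc1ccc2[nH]c(=O)c(CN(Cc3ccccc3)Cc3ccc(C(C)(C)C)cc3)cc2c1` gives > 5000 nM in this assay, which is a limit of the assay and not a number. Compound 3 `CCc1ccc2[nH]c(=O)c(CN(Cc3ccc(O)cc3)Cc3ccc(C(C)(C)C)cc3)cc2c1` gives > 10000 nM in this assay, again a limit. The two measured steps are both small: hydroxy in place of hydrogen on an aromatic carbon gave an at least 1.0-fold lower number from compound 1 to compound 2 (0.00 log units; that floor lies within the scatter), and methyl in place of hydrogen on a saturated chain carbon bound to an aromatic carbon gave an at least 2.0-fold higher number from compound 2 to compound 3 (0.30 log units; that floor lies within the scatter).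

Compound 4 `CCCOc1ccc(CN(Cc2ccc(C(C)(C)C)cc2)Cc2cc3cc(C)ccc3[nH]c2=O)cc1` differs from compound 2 by propyl in place of hydrogen on an oxygen on an aromatic ring. Within the data shown here, no measured step alters a group on that oxygen, so the nearest guidance is the pair of steps just described, neither of which moved the read-out beyond the scatter. On that basis the step of a 1.2-fold higher number from compound 2 to compound 4 (0.09 log units; within the scatter) is expected to be small, in no firm direction, and a limit rather than a number is thought likely for compound 4. Compound 4 is therefore estimated at 6000 nM, with a range from 2500 nM to 15000 nM.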

Compound 4, half-maximal cytotoxic concentration: > 5000 nM
Compound 4: a limit, no number; the forecaster's own chance of this, stated with the estimate: 50%; the middle value lies beyond the limit too.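

In this assay, propyl in place of hydrogen on an oxygen on an aromatic ring gives an at least 1.0-fold higher number from compound 2 to compound 4 (0.00 log units; that floor lies within the scatter), so the only change at this oxygen among the compounds shown has a floor that cannot be told from the scatter. Among these compounds, compound 4 carries a limit of the assay and not a number, and so the 4-propoxybenzyl arm adds a further limit to the series, leaving compound 2 as the only compound with a number: the limit of > 5000 nM in this assay, at which 2 of the 4 values shown sit. The step from compound 1 to compound 4 cannot be read, so replacing hydrogen with propoxy on that aromatic carbon has no readable size.

As far as these compounds go, how far the true value of compound 4 lies past its limit remains open, and with it whether propyl on this oxygen changes the read-out at all. Also open, from the compounds shown here alone, is what the read-out would do with a methyl group, a longer chain such as hexyl, or a chain ending in an amine or a carboxylic acid on the same oxygen, and whether any of these would give a number rather than a limit.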